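Methoxy for hydroxyl in the tail of compound 3

This account rests on a few compounds, and the source may have more. Where it says the series, first, only, none or still open, it means among the compounds named here.

Compound 3 `Cc1cc(OCCCO)cc(C)c1-c1cccc(COc2ccc(OCC(=O)O)c(F)c2)c1`: 110 nM
Compound 1 `COCCCOc1cc(C)c(-c2cccc(COc3ccc(OCC(=O)O)c(F)c3)c2)c(C)c1`: "not determined" (no result reported)
Compound 2 `Cc1cc(OCCOCc2ccccc2)cc(C)c1-c1cccc(COc2ccc(OCC(=O)O)c(F)c2)c1`: "not determined" (no result reported)

In a functional assay on CHO cells for agonist activity at Free fatty acid receptor 1 (Homo sapiens), read by FLIPR and calcium flux (a lower number here means that less compound is needed, a higher number that more compound is needed for the effect), compound 3 gives 110 nM. Within the data shown here, it is the only compound of the three with a number; for compound 1 the result is "not determined" (no result reported) and for compound 2 it is "not determined" (no result reported), so compound 3 cannot be ranked against them. Compound 4 `COCCOc1cc(C)c(-c2cccc(COc3ccc(OCC(=O)O)c(F)c3)c2)c(C)c1` keeps the same atoms joined differently: methoxy in place of hydroxymethyl on a saturated chain carbon, two bonds along the chain from an oxygen on an aromatic ring. Among the measured compounds shown here, no pair of measured compounds shows what such a change does here, so the expected step of a 1.3-fold lower number from compound 3 to compound 4 (0.11 log units; within the scatter) is no larger than the scatter, with a slight lean toward needing less compound. Compound 4 is therefore estimated at 85 nM, between 30 nM and 250 nM.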

Compound 4, half-maximal effective concentration: 104 nM
Estimate against measurement, compound 4: 1.2-fold (0.09 log units) below, within the range that was stated.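

In this assay, the swap of hydroxymethyl for methoxy gives a 1.1-fold lower number from compound 3 to compound 4 (0.02 log units; within the scatter). Among these compounds, this is the first reading at this position: the tail goes from 3-hydroxypropoxy to 2-methoxyethoxy, dropping its one hydrogen-bond donor, and the two compounds cannot be told apart. Nothing available explains this result.

On these data alone, whether an amine or a carboxylic acid on this tail would give a similar number remains open. A single pair also cannot show whether the same swap would read alike on another chain or core.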